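The compounds below may be only part of what the source reports. "The series", "measured", "known", "first", "only" and "open" are said of these compounds alone.

In a functional assay on Jurkat cells (Homo sapiens) for inhibition, read by CCK-8 assay, with a stated time of 48 h; a lower number here means a stronger inhibitor of growth, a higher number a weaker inhibitor of growth:
- compound 1 `Cc1ccccc1Nc1nc(Nc2ccccc2)ncc1Cl`: > 100000 nM
- compound 2 `Cc1ccccc1Nc1nc(Nc2ccc(N3CCCCC3)cc2)ncc1Cl`: > 100000 nM
- compound 3 `Cc1ccc(CNc2nc(Nc3ccc(N4CCN(C)CC4)cn3)ncc2Cl)cc1`: 12700 nM

The entries for compound 1 and compound 2 are limits and not numbers. For the measured compounds named here, compound 3 gives the only number, 12700 nM. The rest of the evidence is the limit of > 100000 nM in this assay, at which 2 of the 3 values shown sit.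

The next step leads to compound 4 `Cc1ccc(Nc2nc(Nc3ccc(N4CCN(C)CC4)cn3)ncc2Cl)cc1`, with 4-methylphenyl in place of 4-methylbenzyl on a nitrogen on an aromatic ring.

Going by the values given here, the only measured step is a step that the two limits leave unreadable from compound 1 to compound 2. Among the compounds with values here, it is a different change and supplies no size, so no measured step bears directly on this one. Compound 1 and compound 2 also lack the 4-methylbenzyl, but they differ from compound 4 elsewhere too, so they only widen the expected range towards weaker values. The expectation therefore stays anchored on compound 3 at 12700 nM, with no shift beyond the scatter in this assay.

The estimated change is a 1.4-fold lower number from compound 3 to compound 4 (0.15 log units; within the scatter).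

Compound 4 is expected at 9000 nM, with an estimated range of 1800 nM to 45000 nM.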

Compound 4, concentration for 50% growth inhibition: 30900 nM
For compound 4 the middle estimate is 3.4-fold (0.54 log units) below the measured one; the range from low to high includes it.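

In this assay, a 2.4-fold higher number from compound 3 to compound 4 (0.39 log units; beyond the scatter), the first readable size in the series: a modest step, but beyond the scatter. On this nitrogen, 4-methylbenzyl therefore gives the lower number of the two groups, while both groups still give numbers and not limits, so the position accepts either one with only a modest change in growth inhibition. The one other step in the series cannot be read, so this change has no second size to stand against: the limit of > 100000 nM in this assay, at which 2 of the 4 values shown sit.

Going by these compounds, whether the step keeps its direction and size with a different group on the shared core stays open, since it rests on this single pair. Also open, on these data alone, is what a longer chain such as 2-phenylethyl on this nitrogen, or an amine in place of the methyl on the ring, would give.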